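The compounds below may be only part of what the source reports. "The series", "measured", "known", "first", "only" and "open" are said of these compounds alone.

Compound 1 `O=C1c2sccc2N(Cc2ccccc2Cl)S(=O)(=O)N1Cc1ccccc1`: in an ADME assay on MT4 cells (Homo sapiens) for cytotoxicity, read by MTT assay, with a stated time of 4 days (a higher number here means that more compound is tolerated, a lower number that less compound is tolerated), compound 1 gives > 298000 nM, which is a limit of the assay and not a number.
Compound 2 `O=C1c2sccc2N(Cc2cccc(Cl)c2)S(=O)(=O)N1Cc1ccccc1`: in this assay compound 2 gives > 298000 nM, again a limit and not a number.
Compound 3 `O=C1c2sccc2N(Cc2ccc([N+](=O)[O-])cc2)S(=O)(=O)N1Cc1ccccc1`: in this assay compound 3 gives 268000 nM.

All three compounds share one core and differ only in the aromatic group hanging from the saturated chain carbon bound to the sulfonamide nitrogen in the ring. Among the compounds with values here, compound 3 thus stands as the only real number in the set, while the other two values sit at the limit of > 298000 nM in this assay, at which 2 of the 3 values shown sit. Within the data shown here, the step of an at least 1.1-fold lower number from compound 1 to compound 3 (0.04 log units; that floor lies within the scatter) and the step of an at least 1.1-fold lower number from compound 2 to compound 3 (0.04 log units; that floor lies within the scatter) both lie within the scatter, and the step that the two limits leave unreadable from compound 1 to compound 2 cannot be read at all, so nothing among the measured compounds points to a change in tolerated concentration when this aromatic group is varied.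

Compound 4 `CN1c2ccsc2C(=O)N(Cc2ccccc2)S1(=O)=O` removes that group altogether: hydrogen in place of 4-nitrophenyl on a saturated chain carbon bound to a sulfonamide nitrogen in a ring. Among the measured compounds shown here, no measured step covers the complete loss of the aromatic group, only its exchange, and those exchanges moved nothing beyond the scatter. The step of a 1.1-fold higher number from compound 3 to compound 4 (0.05 log units; within the scatter) is therefore expected to stay within the scatter. Compound 4 is expected to give about 298000 nM, somewhere between 150000 nM and 600000 nM, quite possibly reported only as a limit.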

Compound 4, half-maximal cytotoxic concentration: 202000 nM
Beside the measured number, compound 4's estimate is 1.5-fold (0.17 log units) above it, and the stated range covers the measured number.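

Unlike the earlier compounds, which only swap one aromatic group for another, compound 4 has a hydrogen atom in place of the whole group on the saturated chain carbon bound to a sulfonamide nitrogen in a ring, and in this assay the result is a 1.3-fold lower number from compound 3 to compound 4 (0.12 log units; within the scatter). Within the data shown here, this is the only step in the set with real numbers at both ends, and it shows that losing the 4-nitrophenyl group, with its one aromatic ring and all of its heavy atoms, does not carry the tolerated concentration beyond the scatter. The steps of an at least 1.4-fold lower number from compound 2 to compound 4 (0.16 log units; that floor lies within the scatter) and an at least 1.4-fold lower number from compound 1 to compound 4 (0.16 log units; that floor lies within the scatter) are floors only, and their true size stays unread because the values of compound 1 and compound 2 are limits and not numbers: the limit of > 298000 nM in this assay, at which 2 of the 4 values shown sit.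

As far as these compounds go, whether any group at this position, such as an amine, a carboxylic acid or a longer chain, would move the tolerated concentration beyond the scatter remains open. From the compounds shown here alone, the rest of the shared core is the same in all four compounds, so what a change elsewhere would do also remains unknown.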